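The compounds below may be only part of what the source reports. "The series", "measured", "known", "first", "only" and "open" are said of these compounds alone.

Values in a functional assay on PC-3 cells (Homo sapiens) for antiproliferative activity, read by MTT assay, with a stated time of 48 h (a higher number here means a weaker inhibitor, a lower number a stronger inhibitor), for the series so far:
- compound 1 `COc1ccc(CN(C(=O)Cn2cc(COc3ccccc3)nn2)c2cc(OC)c(OC)c(OC)c2)cc1` gives 45300 nM
- compound 2 `COc1ccc(CN(C(=O)Cn2cc(CSc3nc4ccccc4s3)nn2)c2cc(OC)c(OC)c(OC)c2)cc1` gives 28500 nM
- compound 3 `COc1ccc(CN(C(=O)Cn2cc(CSC3=NCCS3)nn2)c2cc(OC)c(OC)c(OC)c2)cc1` gives 16000 nM

The starting point for the next change is the third entry, placed by two steps (a 2.8-fold lower number from compound 1 to compound 3 (0.45 log units; beyond the scatter)) and (a 1.8-fold lower number from compound 2 to compound 3 (0.25 log units; within the scatter)). Only the first of these clears the scatter.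

Compound 4 `COc1ccc(CN(C(=O)Cn2cc(CSc3nncs3)nn2)c2cc(OC)c(OC)c(OC)c2)cc1` brings this change (a group of 5 heavy atoms (2 carbon, 2 nitrogen, 1 sulfur; one five-membered aromatic ring with 3 hetero atoms) in place of a group of 5 heavy atoms (3 carbon, 1 nitrogen, 1 sulfur; one five-membered non-aromatic ring with 2 hetero atoms), on a sulfur). The group entering is 1,3,4-thiadiazol-2-yl, on a sulfur whose other neighbours are: saturated chain carbon.

The closest measured step is (a 1.8-fold lower number from compound 2 to compound 3 (0.25 log units; within the scatter)), also on a sulfur, where a group with a five-membered aromatic ring gives way to a five-membered non-aromatic ring. Going by the values given here, the present change runs the other way, so a somewhat higher number is expected in this assay, no larger than that step. The data hold no direct match for this group. The estimated step is small (a 1.6-fold higher number from compound 3 to compound 4 (0.19 log units; within the scatter)). In this assay the estimate for compound 4 is 25000 nM with an expected range (11000 nM to 55000 nM).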

Compound 4, half-maximal inhibitory concentration: 16500 nM
Beside the measured number, compound 4's estimate is 1.5-fold (0.18 log units) above it, within the range that was stated.
By their numbers in this assay, from the lowest: compounds 3, 4, 2 and 1 (each within the scatter of the next, the first and the last beyond it).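

On a sulfur whose other neighbours are a saturated chain carbon, the aromatic 1,3,4-thiadiazol-2-yl and the non-aromatic five-membered ring cannot be told apart in this assay (a 1.0-fold higher number from compound 3 to compound 4 (0.01 log units; within the scatter)). Exchanging 1,3-benzothiazol-2-yl for 1,3,4-thiadiazol-2-yl is also unresolved (a 1.7-fold lower number from compound 2 to compound 4 (0.24 log units; within the scatter)), while exchanging phenoxy for (1,3,4-thiadiazol-2-yl)sulfanyl clears the scatter (a 2.7-fold lower number from compound 1 to compound 4 (0.44 log units; beyond the scatter)), so two of the three sulfur-linked groups now do so against phenoxy, with 1,3-benzothiazol-2-yl the exception. No supporting measurement accounts for any of these steps.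

The phenoxy comparisons change both the linking atom and the ring, so phenylsulfanyl would be needed to separate the two. Also open, going by these compounds, is whether a small chain such as methyl on the sulfur, or an amine or carboxylic acid on the thiadiazole ring, would move the number beyond the scatter.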